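This account rests on a few compounds, and the source may have more. Where it says the series, first, only, none or still open, it means among the compounds named here.

Three compounds share one core and differ only in the aromatic group attached to an aromatic carbon of that core. Compound 1 `CCCS(=O)(=O)Nc1ccc(F)c(C(=O)c2n[nH]c3ncc(-c4cccc(Cl)c4)cc23)c1F` gives 40% in an assay for binding affinity to dual specificity mitogen-activated protein kinase kinase 4 (Homo sapiens), read by KINOMEscan, tested at 100 nM; on this read-out lower numbers stand for a stronger effect and higher numbers for a weaker effect at the one concentration tested. Compound 2 `CCCS(=O)(=O)Nc1ccc(F)c(C(=O)c2n[nH]c3ncc(-c4ccc(F)cc4)cc23)c1F` gives 2.1%, and compound 3 `CCCS(=O)(=O)Nc1ccc(F)c(C(=O)c2n[nH]c3ncc(-c4ccccc4OC)cc23)c1F` gives 1.9%, the lowest of the three numbers. The steps of a number 37.9 percentage points lower from compound 1 to compound 2 (beyond the scatter) and a number 38.1 percentage points lower from compound 1 to compound 3 (beyond the scatter) were large, while a number 0.2 percentage points lower from compound 2 to compound 3 (within the scatter) lay within the scatter. Compound 4 `CCCS(=O)(=O)Nc1ccc(F)c(C(=O)c2n[nH]c3ncc(-c4ccc(N)cc4)cc23)c1F` carries 4-aminophenyl in place of 2-methoxyphenyl on an aromatic carbon. The two steps that replaced 3-chlorophenyl bear on this, as both swaps of the aromatic group away from compound 1 gave strong binding; the swap between compound 2 and compound 3 changed nothing beyond the scatter. A step of a number 3.1 percentage points higher from compound 3 to compound 4 (within the scatter) is therefore expected, and compound 4 is estimated at 5%, between 1% and 35%.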

Compound 4, a percentage reported as activity, at one concentration (the size of the read-out at that concentration, not a potency): 0.1%
Compound 4: the middle estimate sits 4.9 percentage points above what was measured, outside the stated range (below it).
By their numbers in this assay, from the lowest: compounds 4, 3 and 2 (each within the scatter of the next); then compound 1.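

In this assay the steps of a number 1.8 percentage points lower from compound 3 to compound 4 (within the scatter) and a number 2 percentage points lower from compound 2 to compound 4 (within the scatter) show that 4-aminophenyl, which brings a hydrogen-bond donor that 2-methoxyphenyl lacks, fits this position as well as the two groups before it. The step of a number 39.9 percentage points lower from compound 1 to compound 4 (beyond the scatter) leaves compound 1 as the only one of the four apart from the rest. Nothing measured here explains this.

Going by these compounds, whether compound 1 stands apart for its chlorine or for where the chlorine sits stays open, and a 4-chlorophenyl group would help separate the two. On these data alone, the effect of a carboxylic acid on the aromatic ring also remains unknown.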